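The source may report more compounds than this note shows. Statements on the series, on what has been measured and on what is new or still open speak of the compounds shown alone.

Compound 2: `N#CC1=C(N)Oc2c(N)cc3nc4ccccc4nc3c2C12C(=O)N(Cc1cnnn1-c1cccc(Br)c1)c1ccccc12` — 18900 nM
Compound 1: `COc1ccc(-n2nncc2CN2C(=O)C3(C(C#N)=C(N)Oc4c3c3nc5ccccc5nc3c3ccccc43)c3ccccc32)cc1` — > 50000 nM

For the measured compounds named here, in a functional assay on A549 cells (Homo sapiens) for antiproliferative activity, read by MTT assay, with a stated time of 48 h (on this read-out higher numbers stand for weaker inhibition and lower numbers for stronger inhibition), compound 2 gives 18900 nM, the only number that has come back from this series. Compound 1, which carries a different core, gives > 50000 nM in this assay, a limit of the measurement and not a number (the limit of > 50000 nM in this assay, at which 1 of the 2 values shown sits). Going by the values given here, no measured pair differs in a single place, so no step has been measured here.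

Compound 3, `N#CC1=C(N)Oc2c(N)cc3nc4ccccc4nc3c2C12C(=O)N(Cc1cnnn1-c1ccc(Cl)cc1[N+](=O)[O-])c1ccccc12`, has not been measured yet. It differs from compound 2 in one place: 4-chloro-2-nitrophenyl in place of 3-bromophenyl on an aromatic nitrogen.

Among the compounds with values here, with no measured step to lean on, a change on that aromatic nitrogen is expected to move the value of this assay by little, not clearly beyond the scatter, in no set direction. Compound 3 is therefore estimated at 20000 nM, between 6000 nM and 60000 nM, a step of a 1.1-fold higher number from compound 2 to compound 3 (0.02 log units; within the scatter).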

Compound 3, half-maximal inhibitory concentration: > 50000 nM
Compound 3 ended at the assay's limit (the forecaster's own chance of this, stated with the estimate: 35%); at least 2.5-fold (0.39 log units) between middle value and limit.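

For the compounds shown here, this is the first measured step on this aromatic nitrogen, and it shows that the group there is not without effect: in this assay, 4-chloro-2-nitrophenyl in place of 3-bromophenyl gives an at least 2.6-fold higher number from compound 2 to compound 3 (0.42 log units; beyond the scatter). The change removes a bromine and brings in both a chlorine and a nitro group, so this single step cannot be divided among them. Compound 3 gives > 50000 nM, a limit of the assay and not a number, and it joins the other value held there: the limit of > 50000 nM in this assay, at which 2 of the 3 values shown sit.

Open, from the compounds shown here alone, is whether the nitro group or the chlorine alone would give the same step, and how far the true value of compound 3 lies past the limit. Also open, going by these compounds, is whether a plain phenyl, an aminophenyl or a carboxylic acid on that ring would give a lower number than compound 2, at 18900 nM.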